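The compounds below may be only part of what the source reports. "The series", "measured", "known", "first", "only" and "open" are said of these compounds alone.

Measured so far in a functional assay on HCC1937 cells (Homo sapiens) for antiproliferative activity, read by CCK-8 assay, with a stated time of 72 h; on this read-out higher numbers stand for weaker inhibition and lower numbers for stronger inhibition:
compound 1 `O=C(Nc1cccc(-c2oc3cc(-c4ccc(F)cc4)ccc3c(=O)c2O)c1)c1ccc(F)cc1` gives 14200 nM;
compound 2 `Cc1ccc(C(=O)Nc2cccc(-c3oc4cc(-c5ccc(F)cc5)ccc4c(=O)c3O)c2)cc1` gives 7110 nM;
compound 3 `O=C(Nc1cccc(-c2oc3cc(-c4ccc(F)cc4)ccc3c(=O)c2O)c1)c1ccc(F)cc1F` gives 6980 nM.

Compound 1 stands at the highest number of the three. The step of a 2.0-fold lower number from compound 1 to compound 2 (0.30 log units; within the scatter) is small, and the step of a 2.0-fold lower number from compound 1 to compound 3 (0.31 log units; beyond the scatter) is only a little larger. Compound 4 `COc1cccc(C(=O)Nc2cccc(-c3oc4cc(-c5ccc(F)cc5)ccc4c(=O)c3O)c2)c1` has not yet been measured; it differs from compound 1 in one place: 3-methoxyphenyl in place of 4-fluorophenyl on a carbonyl carbon. All three measured steps concern the group on that carbonyl carbon. The step of a 2.0-fold lower number from compound 1 to compound 2 (0.30 log units; within the scatter) put methyl in place of fluoro, the step of a 2.0-fold lower number from compound 1 to compound 3 (0.31 log units; beyond the scatter) put fluoro in place of hydrogen, and the step of a 1.0-fold lower number from compound 2 to compound 3 (0.01 log units; within the scatter) exchanged the whole aryl group. None of them moved the number far, and none raised it. The change to compound 4 is of the same kind, so a step that is small or not beyond the scatter, and if anything toward a lower number, is expected. Relative to compound 1, compound 4 is expected at a 1.6-fold lower number from compound 1 to compound 4 (0.20 log units; within the scatter). The estimate for compound 4 is 9000 nM, with a range from 4000 nM to 18000 nM.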

Compound 4, half-maximal inhibitory concentration: 18900 nM
Estimate against measurement, compound 4: 2.1-fold (0.32 log units) below, and the stated range ends below it.
By their numbers in this assay, from the lowest: compounds 3, 2, 1 and 4 (each within the scatter of the next, the first and the last beyond it).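

In this assay, the step of a 1.3-fold higher number from compound 1 to compound 4 (0.12 log units; within the scatter) shows that 3-methoxyphenyl can take the place of 4-fluorophenyl on the carbonyl carbon with no difference beyond the scatter. Unlike the earlier steps at this position, a 2.7-fold higher number from compound 3 to compound 4 (0.43 log units; beyond the scatter) and a 2.7-fold higher number from compound 2 to compound 4 (0.42 log units; beyond the scatter) both lead to a higher number and lie beyond the scatter, so the choice of aryl group here now has a modest but readable effect. Nothing available accounts for these differences.

The compounds shown leave open whether the methoxy group itself or its place on the ring sets the number for compound 4, as 3-methoxyphenyl and 4-fluorophenyl differ in both. Also open, on these data alone, is how a 4-methoxyphenyl, pyridyl or cyclohexyl group on this carbonyl carbon would read.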